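A few compounds are considered here, and "the series" means these few. Any claim that something is new, unique, unknown or untested is made for them only; others in the source may bear on it.

Compound 1 `COCCCCCCCCCCCCCCC/C=C1/CC(CO)(COC(=O)C(C)(C)C)OC1=O`: 6.77 ug/mL
Compound 2 `COCCCCCCCCCCC/C=C1\CC(CO)(COC(=O)C(C)(C)C)OC1=O`: 7.34 ug/mL
Compound 3 `CCCCCCCCC(O)CCCCCC/C=C1\CC(CO)(COC(=O)C(C)(C)C)OC1=O`: > 10 ug/mL

All three were read out in a functional assay on Hs-578T cells (Homo sapiens) for antiproliferative activity; on this read-out higher numbers stand for weaker inhibition of growth and lower numbers for stronger inhibition of growth. Compound 2 at 7.34 ug/mL lies within the scatter of compound 1 at 6.77 ug/mL. Compound 3 gives > 10 ug/mL, which is a limit and not a number.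

Compound 4 `CCCCCOCCCCCCC/C=C1\CC(CO)(COC(=O)C(C)(C)C)OC1=O` differs from compound 2 as follows: pentyloxy in place of 4-methoxybutyl on a saturated chain carbon, seven bonds along the chain from a double-bonded chain carbon. The two have the same atoms, joined differently. Within the data shown here, the only measured step on this chain is an at least 1.3-fold higher number from compound 2 to compound 3 (0.13 log units; that floor lies within the scatter). It is a different exchange and a floor only, so it is a weak guide, and no shift beyond the scatter is expected in this assay. The expected step is a 1.0-fold higher number from compound 2 to compound 4 (0.01 log units; within the scatter). For compound 4 the estimate is 7.5 ug/mL, with an expected range of 4 ug/mL to 12 ug/mL.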

Compound 4, concentration for 50% growth inhibition: 3 ug/mL
Compound 4: the middle estimate sits 2.5-fold (0.40 log units) above what was measured; measured number outside the range, below it.
By their numbers in this assay, from the lowest: compound 4; then compounds 1 and 2 (each within the scatter of the next). At a limit, above all of these: compound 3.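

In this assay the chain is sensitive to how its atoms are joined, even with the same atoms: pentyloxy in place of 4-methoxybutyl gives a 2.4-fold lower number from compound 2 to compound 4 (0.39 log units; beyond the scatter) at this place on the chain. The (pentyloxy)methyl exchange for 1-hydroxynonyl gives an at least 3.3-fold lower number from compound 3 to compound 4 (0.52 log units; beyond the scatter) and so also goes beyond the scatter. Compound 3 stands at a limit and not at a number: the limit of > 10 ug/mL in this assay, at which 1 of the 4 values shown sits.

Open, as far as these compounds go, is whether the step persists with the ether oxygen at other places along the chain. Also open, from the compounds shown here alone, is how an amine or a carboxylic acid at the chain end would read here.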